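The source may hold more compounds than are shown below. What is called first, only, known or untested is meant among the compounds shown, and "the series" means these compounds.

Measured so far:
compound 1, `Cc1cc(C)cc(NC(=O)COc2cc(C)nc3ccc(Cl)cc23)c1`, 6.38 in a physicochemical assay for lipophilicity, read by HPLC, in phosphate buffer, measured as chromatographic lipophilicity, at pH 7.4; a higher number here means a more lipophilic compound, a lower number a more polar compound
compound 2, `COc1ccc2nc(C)cc(OCC(=O)NCc3cc(C)cc(C)c3)c2c1`, 5.25

Compound 2 stands lowest of the two numbers in this assay; its nearest neighbour is compound 1, which lies higher by a gap beyond the scatter. Going by the values given here, no pair of measured compounds differs in one place, so no measured step is available.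

Compound 3, `COc1ccc2nc(C)cc(OCC(=O)Nc3cc(C)nc(C)n3)c2c1`, is not yet measured. Its change from compound 2: 2,6-dimethylpyrimidin-4-yl in place of 3,5-dimethylbenzyl on an amide-type nitrogen. The expected step from compound 2 to compound 3 is downward and beyond the scatter, about a number 1.95 log units lower from compound 2 to compound 3 (beyond the scatter). Compound 3 is estimated at 3.3, within 2.5 to 4.1.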

Compound 3, distribution coefficient: 3.24
For compound 3 the middle estimate is 0.06 log units above the measured one; measured number inside the range.
By their numbers in this assay, from the lowest: compound 3; then compound 2; then compound 1.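

Compound 3 gives the series its first one-place step, with 2,6-dimethylpyrimidin-4-yl in place of 3,5-dimethylbenzyl on the amide-type nitrogen: a number 2.01 log units lower from compound 2 to compound 3 (beyond the scatter) in this assay. The number therefore moves by a large step with the group at this place while the rest of the molecule stays fixed. Nothing available accounts for the size of this step.

The step changes the ring atoms and removes the benzyl carbon together, so their shares remain separate unknowns. A 3,5-dimethylphenyl group on the same nitrogen could divide them.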